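The compounds below may be only part of what the source reports. "The series", "measured", "known", "first", "only" and "open" are said of these compounds alone.

Compound 1 `CCCCCNC(=O)/C=C/c1ccccc1`: 76%
Compound 2 `CCC(C)OC(=O)/C=C/c1ccccc1`: 20%
Compound 3 `CCC(C)NC(=O)/C=C/c1ccccc1`: 77%

In a functional assay on the whole organism for inhibition, with Brassica rapa subsp. chinensis as the target, with a stated time of 3 days, tested at 100 ppm (a higher number here means more inhibition of growth at the concentration tested, a lower number less inhibition of growth), compound 3 gives 77% and so sits level with compound 1 within the scatter and well clear of compound 2. The next structure, compound 4 `CC(C)CNC(=O)/C=C/c1ccccc1`, has isobutyl in place of sec-butyl on an amide-type nitrogen is the whole change. Among the measured compounds shown here, the closest precedent is a number 1 percentage points higher from compound 1 to compound 3 (within the scatter) where sec-butyl replaced pentyl on that same nitrogen. The large a number 57 percentage points higher from compound 2 to compound 3 (beyond the scatter) came from putting (sec-butyl)amino in place of sec-butoxy on a carbonyl carbon, an exchange not repeated here. The expected step is a number 2 percentage points lower from compound 3 to compound 4 (within the scatter) and so none beyond the scatter. In this assay the estimate for compound 4 is 75% with an expected range from 62% to 87% as the likely span.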

Compound 4, percent growth inhibition at one concentration: 78%
Compound 4: middle estimate off by 3 percentage points, on the low side; low and high end bracket the measured number.
By their numbers in this assay, from the lowest: compound 2; then compounds 1, 3 and 4 (each within the scatter of the next).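

Isobutyl in place of sec-butyl on the amide-type nitrogen gives a number 1 percentage points higher from compound 3 to compound 4 (within the scatter) in this assay, so joining the same atoms differently at this position has no readable effect. Isopropyl in place of butyl on a saturated chain carbon bound to an amide-type nitrogen likewise gives a number 2 percentage points higher from compound 1 to compound 4 (within the scatter). Isobutylamino in place of sec-butoxy on a carbonyl carbon gives a number 58 percentage points higher from compound 2 to compound 4 (beyond the scatter), so the large step is not tied to the sec-butyl chain.

Going by these compounds, whether a carboxylic acid, an amine or a much longer chain on this nitrogen would keep the number remains open. Nothing available explains these results.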